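Series notes: acid versus ester on the imidazole ethers

A few compounds are considered here, and "the series" means these few. Any claim that something is new, unique, unknown or untested is made for them only; others in the source may bear on it.

Measured so far:
compound 1 `COc1ccc(COCC(Cn2ccnc2)OCCCCCCC(=O)O)cc1`: 1890 nM
compound 2 `CCOC(=O)CCCCCCOC(COCc1ccc(OC)cc1)Cn1ccnc1`: 4000 nM

In a functional assay on a cell-free system (plasma) for inhibition of Thromboxane-A synthase (Homo sapiens) (a lower number here means a stronger inhibitor, a higher number a weaker inhibitor), compound 2 gives 4000 nM, the highest of the two numbers recorded; its nearest neighbour is compound 1, which in this assay gives 1890 nM. Among the compounds with values here, the only step recorded between them is a 2.1-fold higher number from compound 1 to compound 2 (0.33 log units; beyond the scatter), with ethyl in place of hydrogen on an oxygen next to a carbonyl group.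

Compound 3 `COc1ccc(COCC(Cn2ccnc2)OCCC/C=C/C(=O)O)cc1` is not yet measured. It differs from compound 2 in that (2-carboxyethenyl in place of 3-(ethoxycarbonyl)propyl on a saturated chain carbon, three bonds along the chain from an oxygen on a saturated carbon). Within the data shown here, this change returns the free carboxylic acid of compound 1 but also shortens the chain and introduces a double bond; for the chain shortening and the unsaturation no measured pair exists.

The ester-to-acid part of the change is the reverse of the recorded step a 2.1-fold higher number from compound 1 to compound 2 (0.33 log units; beyond the scatter), so a step down of about that size is expected, with added uncertainty from the chain. The expected step is a 2.4-fold lower number from compound 2 to compound 3 (0.37 log units; beyond the scatter). For compound 3 in this assay the estimate is 1700 nM, in the range 500 nM to 5500 nM.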

Compound 3, half-maximal inhibitory concentration: 8330 nM
Compound 3: the middle estimate sits 4.9-fold (0.69 log units) below what was measured; the measured number lies above the stated range.
By their numbers in this assay, from the lowest: compound 1; then compound 2; then compound 3.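

In this assay, the free acid does not by itself bring the lower number: 2-carboxyethenyl in place of 3-(ethoxycarbonyl)propyl gives a 2.1-fold higher number from compound 2 to compound 3 (0.32 log units; beyond the scatter), the opposite direction to the ester-to-acid comparison within the earlier pair. With the acid present on both sides, 2-carboxyethenyl in place of 3-carboxypropyl gives a 4.4-fold higher number from compound 1 to compound 3 (0.64 log units; beyond the scatter), so this position, three bonds along the chain from an oxygen on a saturated carbon, responds to a change in the chain even when the carboxylic acid is retained, and the size of the ester-to-acid step in the earlier pair does not carry over to this chain. Nothing in the data at hand accounts for the higher number of compound 3.

The shortening of the chain and the double bond arrive together in compound 3, and the compounds shown do not separate them. Also open, going by these compounds, is how a saturated carboxylic acid chain of the same length as in compound 3, the ethyl ester of compound 3, or a tetrazole in place of the carboxylic acid would read in this assay.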